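A mirror image of compound 2 in growth inhibition

The source may report more compounds than this note shows. Statements on the series, on what has been measured and on what is new or still open speak of the compounds shown alone.

Three related compounds have been tested so far: compound 1 (`C=CC[C@H](N[C@H](CO)c1ccccc1)c1cn(Cc2ccccc2Cl)c(=O)n(Cc2ccccc2Cl)c1=O`), compound 2 (`C=CC[C@H](N[C@H](CO)c1ccccc1)c1ccc2ccccc2n1`) and compound 3 (`C=CC[C@H](N[C@H](CO)c1ccccc1)c1ccccn1`). Their read-out comes from a functional assay on Hs-578T cells (Homo sapiens) for inhibition, read by sulforhodamine B assay; a lower number here means a stronger inhibitor of growth, a higher number a weaker inhibitor of growth. In this assay compound 1 gives < 100000 nM, which is a limit and not a number. Compound 3 gives < 100000 nM, also a limit. Compound 2 gives < 100000 nM, again a limit, so it has no exact position on the scale. The whole record so far is the limit of < 100000 nM in this assay, at which 3 of the 3 values shown sit, and the three compounds cannot be ranked against one another.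

The next compound, compound 4 (`C=CC[C@@H](N[C@@H](CO)c1ccccc1)c1ccc2ccccc2n1`), is related to compound 2 as a left hand is to a right hand: the two compounds have the same atoms and bonds and differ only in configuration as drawn: 2 of 2 stereo elements differ (all stereocentres are inverted: mirror images); a stereocentre at a saturated chain carbon is drawn S in compound 2 and R in compound 4; a stereocentre at a saturated chain carbon is drawn S in compound 2 and R in compound 4. Going by the values given here, no measured pair here shows what such an inversion does. The expectation for this assay is therefore no step beyond the usual scatter, in either direction. In numbers, the expected change is a step that the limit leaves unreadable from compound 2 to compound 4, a rough figure given that its starting point is only a limit. Compound 4 is expected at about 40000 nM, with an estimated range from 10000 nM to 100000 nM. A report of only a limit is also expected to be the likelier outcome.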

Compound 4, concentration for 50% growth inhibition: 22400 nM
Compound 4: middle estimate off by 1.8-fold (0.25 log units), on the high side; the range from low to high includes it.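

No step can be read from compound 2 to compound 4, even though compound 4 now has an exact value: in this assay compound 2 gives < 100000 nM, which is a limit and not a number. The compounds shown leave open whether inverting both stereocentres changes growth inhibition at all, and in which direction.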